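Swapping an Oxygen for Fluorine on Compound 1

The source may hold more compounds than are shown below. What is called first, only, known or untested is meant among the compounds shown, and "the series" means these compounds.

Compound 1 `COCCOCn1cc[n+](C)c1/C=N/O` gives -2.81 in a physicochemical assay for lipophilicity (on this read-out lower numbers stand for lower lipophilicity and higher numbers for higher lipophilicity), the lowest of the three values at hand; compound 2 `C[n+]1ccn(COCC[Si](C)(C)C)c1/C=N/O` gives -0.34 and compound 3 `C[n+]1ccn(COCCC[Si](C)(C)C)c1/C=N/O` gives 0.43. Compound 4 `C[n+]1ccn(CCOCCF)c1/C=N/O` differs from compound 1 by (2-fluoroethoxy)methyl in place of 2-methoxyethoxy on a saturated chain carbon bound to an aromatic nitrogen. Among the measured compounds shown here, the steps that bear on this are a number 2.47 log units higher from compound 1 to compound 2 (beyond the scatter) and a number 3.24 log units higher from compound 1 to compound 3 (beyond the scatter); both were large, but each put a silicon-bearing group in place of a smaller group, whereas the move to compound 4 keeps the chain length and trades one oxygen for one fluorine. For the measured compounds named here, no measured step shows exactly that trade. A modest rise is therefore expected: a number 0.61 log units higher from compound 1 to compound 4 (beyond the scatter). Compound 4 is estimated at -2.2, with a likely range from -2.8 to -1.5.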

Compound 4, distribution coefficient: -2.62
Estimate against measurement, compound 4: 0.42 log units above; the range from low to high includes it.
By their numbers in this assay, from the lowest: compounds 1 and 4 (each within the scatter of the next); then compound 2; then compound 3.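

In this assay, (2-fluoroethoxy)methyl in place of 2-methoxyethoxy on a saturated chain carbon bound to an aromatic nitrogen gives a number 0.19 log units higher from compound 1 to compound 4 (within the scatter), so the two compounds cannot be told apart. Among the compounds shown here, the large steps seen earlier came with silicon-bearing groups; this chain of 5 heavy atoms, with fluorine taking the place of one oxygen, gives no such step. Nothing at hand gives a reason for this.

Still open, from the compounds shown here alone, is what a group with an amine or a carboxylic acid would do at this place. A longer fluorine-bearing chain is also untested among the compounds shown.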